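This account rests on a few compounds, and the source may have more. Where it says the series, first, only, none or still open, it means among the compounds named here.

Two compounds have so far been run through an ADME assay on microsomes from liver (Homo sapiens) for metabolic stability, read by LC-MS, with a stated time of 45 min, tested at 2 uM; on this read-out higher numbers stand for a more stable compound and lower numbers for a less stable compound. Compound 1 `Cc1cc(OCc2ccc(F)cc2F)c(Br)c(=O)n1Cc1ccc(CN(C)C)cc1` gives 57% in this assay, and compound 2 `O=c1c(Br)c(OCc2ccc(F)cc2F)ccn1Cc1cccc(F)c1` gives 48%; these two numbers lie within the usual scatter of each other, so neither can be called the more stable. Compound 3 `Cc1cc(OCc2ccc(F)cc2F)c(Br)c(=O)n1Cc1cccc(CN(C)C)c1` has the same atoms as compound 1, joined differently: 3-((dimethylamino)methyl)phenyl in place of 4-((dimethylamino)methyl)phenyl on a saturated chain carbon bound to an aromatic nitrogen. Among the compounds with values here, no measured pair shows what such a change does here. A step of this kind is expected to stay within the scatter, a number 2 percentage points lower from compound 1 to compound 3 (within the scatter). Compound 3 is estimated at 55%, with a range from 35% to 75%.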

Compound 3, percent of the compound remaining: 50%
Compound 3: the middle estimate sits 5 percentage points above what was measured; the measured number falls inside the stated range.
By their numbers in this assay, from the lowest: compounds 2, 3 and 1 (each within the scatter of the next).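

Within the data shown here, compound 1 and compound 3 form the first pair here that differs in only one place, and this assay gives a number 7 percentage points lower from compound 1 to compound 3 (within the scatter) for 3-((dimethylamino)methyl)phenyl in place of 4-((dimethylamino)methyl)phenyl on a saturated chain carbon bound to an aromatic nitrogen. In this pair, the read-out cannot tell the two arrangements apart. No measurement available here offers an explanation for this result. Still open, going by these compounds, is whether a morpholine or a carboxylic acid in place of the dimethylamino group would give a step beyond the usual scatter.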